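A few compounds are considered here, and "the series" means these few. Any claim that something is new, unique, unknown or untested is made for them only; others in the source may bear on it.

Measured so far:
compound 1 `COc1ccc(CNc2cc(Oc3ccc(NC(=O)Nc4ccc(C)c(C(F)(F)F)c4)cc3)ncn2)cc1` — 1000 nM
compound 2 `Cc1ccc(NC(=O)Nc2ccc(Oc3cc(N4CCNC[C@H]4C)ncn3)cc2)cc1C(F)(F)F` — 9670 nM
compound 3 `CNCCN(C)c1cc(Oc2ccc(NC(=O)Nc3ccc(C)c(C(F)(F)F)c3)cc2)ncn1` — > 10000 nM

Compound 1 is the reference point of the set. In a functional assay on BaF3 cells (Mus musculus) for inhibition, read by CCK-8 assay, with a stated time of 72 h (a lower number here means a stronger inhibitor of growth, a higher number a weaker inhibitor of growth), compound 1 gives 1000 nM. Replacing its (4-methoxybenzyl)amino with 2-methylpiperazin-1-yl gives a 9.7-fold higher number from compound 1 to compound 2 (0.99 log units; beyond the scatter), so compound 2 sits at 9670 nM. For compound 3 the assay returns only a limit, > 10000 nM; this is the limit of > 10000 nM in this assay, at which 1 of the 3 values shown sits, not a number. The change from compound 1 is read as an at least 10-fold higher number from compound 1 to compound 3 (1.00 log units; beyond the scatter), and between the two weaker compounds an at least 1.0-fold higher number from compound 2 to compound 3 (0.01 log units; that floor lies within the scatter).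

Compound 4 `C=CC(=O)Nc1cc(Oc2ccc(NC(=O)Nc3ccc(C)c(C(F)(F)F)c3)cc2)ncn1` is the next compound in this series. Its difference from compound 3 is (vinylcarbonyl)amino in place of methyl(2-(methylamino)ethyl)amino on an aromatic carbon. For the measured compounds named here, the entering group has no chain amine and is smaller, so none of the measured steps covers it directly; the two steps from compound 1 only show that both replacements of the benzylamino group tried so far weakened the inhibitor, and the step from compound 2 to compound 3 shows no separation beyond the scatter.

The estimate for compound 4 is therefore uncertain and wide: compound 4 is expected at 2500 nM, between 300 nM and 10000 nM. Expressed as a step from the limit of compound 3, the expected change is an at least 4.0-fold lower number from compound 3 to compound 4 (0.60 log units; beyond the scatter), with a real chance that this assay again reports only a limit.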

Compound 4, concentration for 50% growth inhibition: 1940 nM
Compound 4: the middle estimate sits 1.3-fold (0.11 log units) above what was measured; measured number inside the range.
By their numbers in this assay, from the lowest: compounds 1 and 4 (each within the scatter of the next); then compound 2. At a limit, above all of these: compound 3.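

In this assay, (vinylcarbonyl)amino on this aromatic carbon, next to the ring nitrogen, is the only replacement shown that does not separate from the (4-methoxybenzyl)amino group of the reference, with a 1.9-fold higher number from compound 1 to compound 4 (0.29 log units; within the scatter), so a reading of this order at this position does not depend on the 4-methoxybenzyl group. Against the other replacements, the same group gives a 5.0-fold lower number from compound 2 to compound 4 (0.70 log units; beyond the scatter) and an at least 5.1-fold lower number from compound 3 to compound 4 (0.71 log units; beyond the scatter), so the loss seen with 2-methylpiperazin-1-yl and methyl(2-(methylamino)ethyl)amino does not follow from removing the benzylamino group as such. The step from compound 3 rests on a limit and not on a number, so its true size stays unknown: the limit of > 10000 nM in this assay, at which 1 of the 4 values shown sits.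

Open, on these data alone, is whether the double bond of (vinylcarbonyl)amino has any part in this reading, a question that a saturated propanoylamino group at the same carbon would address. Also open, as far as these compounds go, is how a plain amino group or an unsubstituted benzylamino group would read here, and so whether the size of the entering group or the presence of its carbonyl tracks with the values at this position.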